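The source may hold more compounds than are shown below. What is called first, only, known or untested is meant among the compounds shown, and "the series" means these compounds.

In a functional assay on HCT-116 cells (Homo sapiens) for inhibition, read by sulforhodamine B assay, with a stated time of 48 h (on this read-out lower numbers stand for stronger inhibition of growth and higher numbers for weaker inhibition of growth), compound 2 (`CC(C)c1cc(C(=O)Nc2ccc(NC(=O)CCCCCCC(=O)NO)cc2)c(O)cc1O`) gives 5430 nM and compound 1 (`CCN(C(=O)c1cc(C(C)C)c(O)cc1O)c1ccc(NC(=O)CCCCCCC(=O)NO)cc1`) gives 3560 nM in the same test. Within the data shown here, compound 2 therefore stands within the scatter of compound 1, its only measured neighbour. Among the measured compounds shown here, the one measured step, a 1.5-fold higher number from compound 1 to compound 2 (0.18 log units; within the scatter) and so no real shift, comes with hydrogen in place of ethyl on an amide-type nitrogen.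

Compound 3 (`CC(C)c1cc(C(=O)N(c2ccc(NC(=O)CCCCCCC(=O)NO)cc2)C(C)C)c(O)cc1O`) differs from compound 2 by isopropyl in place of hydrogen on an amide-type nitrogen with isopropyl in place of hydrogen on that amide-type nitrogen. For the measured compounds named here, only the step between the two measured compounds touches this nitrogen, and no measured compound carries isopropyl there. A change beyond the scatter is therefore not expected in this assay from this substitution. The expectation leans slightly towards compound 1 (3560 nM) as the measured compound with a carbon group on that nitrogen. The expected step is a 1.6-fold lower number from compound 2 to compound 3 (0.19 log units; within the scatter) and this remains an estimate until the measurement is made. Compound 3 is estimated at 3500 nM with an expected range from 1500 nM to 8000 nM in this test.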

Compound 3, concentration for 50% growth inhibition: > 10000 nM
Compound 3 gave a limit, no number (the forecaster's own chance of this, stated with the estimate: 3%); middle value at least 2.8-fold (0.45 log units) away from the limit.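

For compound 3 the result in this assay is a limit of the assay and not a number: the limit of > 10000 nM in this assay, at which 1 of the 3 values shown sits. Hydrogen and ethyl on this amide-type nitrogen had read within the scatter of each other, and the comparison with hydrogen still does not settle the matter for isopropyl, which gives an at least 1.8-fold higher number from compound 2 to compound 3 (0.26 log units; that floor lies within the scatter). The comparison with ethyl does show a real change, as methyl in place of hydrogen on a saturated chain carbon bound to an amide-type nitrogen and a saturated chain carbon gives an at least 2.8-fold higher number from compound 1 to compound 3 (0.44 log units; beyond the scatter), so this position, which had shown no real shift, responds to a single added methyl with weaker inhibition of growth.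

On these data alone, the size of the change remains open, as the limit for compound 3 gives only a floor for both steps, and the true distance from the other two compounds cannot be read from it. Also open, as far as these compounds go, is how a straight propyl chain, a cyclopropyl ring or a chain ending in an amine on this amide-type nitrogen would read in this assay.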